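The source may report more compounds than this note shows. Statements on the series, on what has been measured and on what is new or still open speak of the compounds shown alone.

Series notes. In a functional assay on HT-29 cells (Homo sapiens) for inhibition, read by MTT assay, with a stated time of 72 h (on this read-out higher numbers stand for weaker inhibition of growth and lower numbers for stronger inhibition of growth), compound 3 `O=S(=O)(NCCCNCc1ccc(Br)cc1)c1cc(C(F)(F)F)cc(C(F)(F)F)c1` gives 2200 nM, the second highest of three numbers. Compound 1 `CC(C)(C)c1ccc(CNCCCNS(=O)(=O)c2cc(C(F)(F)F)cc(C(F)(F)F)c2)cc1` gives 2000 nM and compound 2 `O=S(=O)(NCCCNCc1ccc(Cl)c(C(F)(F)F)c1)c1cc(C(F)(F)F)cc(C(F)(F)F)c1` gives 11000 nM. The step of a 1.1-fold higher number from compound 1 to compound 3 (0.04 log units; within the scatter) stays within the scatter, whereas the step of a 5.0-fold lower number from compound 2 to compound 3 (0.70 log units; beyond the scatter) lies beyond it. Compound 4 `O=S(=O)(NCCCNCc1cccc(Cl)c1)c1cc(C(F)(F)F)cc(C(F)(F)F)c1` carries 3-chlorophenyl in place of 4-bromophenyl on a saturated chain carbon bound to an amine nitrogen. For the measured compounds named here, no measured step swaps one single halogen for another on the ring attached to the saturated chain carbon bound to an amine nitrogen; the nearest guides are a 1.1-fold higher number from compound 1 to compound 3 (0.04 log units; within the scatter) and a 5.0-fold lower number from compound 2 to compound 3 (0.70 log units; beyond the scatter), one flat, one modest. A step in this assay of no more than modest size is therefore expected, most likely within the scatter. Compound 4 is estimated at 3000 nM, with a range of 1200 nM to 8000 nM, which means an expected step of a 1.4-fold higher number from compound 3 to compound 4 (0.13 log units; within the scatter).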

Compound 4, concentration for 50% growth inhibition: 14000 nM
For compound 4 the middle estimate is 4.7-fold (0.67 log units) below the measured one; the whole stated range lies below it.
By their numbers in this assay, from the lowest: compounds 1 and 3 (each within the scatter of the next); then compounds 2 and 4 (each within the scatter of the next).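

In this assay, the ring on the saturated chain carbon bound to an amine nitrogen does not allow free exchange of one single halogen for another: 3-chlorophenyl gives a 6.4-fold higher number from compound 3 to compound 4 (0.80 log units; beyond the scatter), and against 4-(tert-butyl)phenyl, a 7.0-fold higher number from compound 1 to compound 4 (0.85 log units; beyond the scatter). With a 1.3-fold higher number from compound 2 to compound 4 (0.10 log units; within the scatter), the rings of compounds 2 and 4, both named with a 3-substituent, group together, apart from the 4-substituted rings of compounds 1 and 3. No available evidence bears on this result.

As far as these compounds go, whether the kind of halogen or its place on the ring carries the change stays open; 3-bromophenyl and 4-chlorophenyl would separate the two.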